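The source may report more compounds than this note shows. Statements on the series, on what has been measured and on what is new or still open speak of the compounds shown alone.

Of the compounds shown here, three built on a shared core have been measured in a functional assay on AGS cells (Homo sapiens) for inhibition, read by MTT assay, with a stated time of 48 h; on this read-out higher numbers stand for weaker inhibition of growth and lower numbers for stronger inhibition of growth. Compound 1 `O=[N+]([O-])c1cccc(-c2cc(-c3ccccc3)n[nH]2)c1` gives 11400 nM in this assay. Compound 2 `COc1ccc(-c2cc(-c3ccc(C(F)(F)F)cc3)n[nH]2)cc1` gives 14800 nM, and compound 3 `FC(F)(F)c1ccc(-c2cc(-c3ccccc3-c3ccccc3)n[nH]2)cc1` gives 6900 nM. Of the three numbers, compound 3 holds the lowest. The gap between compound 3 and compound 1 lies within the usual scatter of repeated measurements, so no order between those two can be read from this assay. The gap between compound 3 and compound 2 lies beyond the scatter, and on those two values compound 3 inhibits growth more strongly than compound 2.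

Compound 4 `O=[N+]([O-])c1ccc(-c2cc(-c3ccccc3-c3ccccc3)n[nH]2)cc1` has not yet been measured. It differs from compound 3 in one place: nitro in place of trifluoromethyl on an aromatic carbon. Within the data shown here, no pair of measured compounds differs by this change alone, so no measured step is available for it. Compound 1 also carries a nitro group and gives 11400 nM, but it lacks the second phenyl ring that compound 3 and compound 4 share, so its value does not isolate the swap. The step is therefore expected to be small, with no direction beyond the scatter: a 1.2-fold higher number from compound 3 to compound 4 (0.06 log units; within the scatter). Compound 4 is expected to give about 8000 nM in this assay, within a range from 3000 nM to 20000 nM.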

Compound 4, concentration for 50% growth inhibition: 1200 nM
Compound 4: the middle estimate sits 6.7-fold (0.82 log units) above what was measured, outside the stated range (below it).
By their numbers in this assay, from the lowest: compound 4; then compounds 3, 1 and 2 (each within the scatter of the next, the first and the last beyond it).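

In this assay, placing nitro in place of trifluoromethyl on an aromatic carbon, para to a large group, gives a 5.8-fold lower number from compound 3 to compound 4 (0.76 log units; beyond the scatter), and this lower number stands for stronger inhibition of growth. The earlier compounds shown here included no pair differing in one place, so they could not show what a single change does; this step shows that, with the rest of the structure held fixed, the group at this position alone can move the number beyond the scatter. What lies behind the step cannot be said, as no measurement bearing on its cause is available here.

The compounds shown give only two groups at this position, so it remains open whether the stronger inhibition is particular to nitro or would also appear with a nitrile, an amine or a carboxylic acid. Going by these compounds, it also remains open whether the same change would give a step of similar size and direction on a compound without the second phenyl ring that compound 3 and compound 4 share.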